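Allyl for propyl on the ring amine of compound 2

A few compounds are considered here, and "the series" means these few. Any claim that something is new, unique, unknown or untested is made for them only; others in the source may bear on it.

Measured so far:
Compound 1 `CN1CCC2CC(C1)c1ccccc12`: 4.2 mg/kg
Compound 2 `CCCN1CCC2CC(C1)c1ccccc12`: 16.2 mg/kg

Within the data shown here, in a functional assay on the whole organism with Mus musculus as the target, in the hot plate test (on this read-out lower numbers stand for an effect already at smaller amounts and higher numbers for an effect only at larger amounts of compound), compound 2 gives 16.2 mg/kg, the highest of the two numbers known here. Among the measured compounds shown here, its nearest neighbour is compound 1, and the only measured step, a 3.9-fold higher number from compound 1 to compound 2 (0.59 log units; beyond the scatter), separates the two. Compound 3 `C=CCN1CCC2CC(C1)c1ccccc12` is not yet measured. It differs from compound 2 by vinyl in place of ethyl on a saturated chain carbon bound to an amine nitrogen in a ring.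

For the measured compounds named here, no measured step bears directly on this exchange: the step from compound 1 to compound 2 replaced hydrogen by ethyl on the chain carbon bound to the ring amine nitrogen, whereas the move to compound 3 keeps the chain length and only introduces a double bond at its far end. Given that the one known step was modest and the present change is smaller in kind, the number for compound 3 is expected to stay close to that of compound 2, with at most a small shift in either direction, expressed as a 1.2-fold higher number from compound 2 to compound 3 (0.09 log units; within the scatter). Compound 3 is therefore estimated at 20 mg/kg, with a range from 7 mg/kg to 60 mg/kg.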

Compound 3, dose for half-maximal effect: 19.4 mg/kg
For compound 3 the middle estimate is 1.0-fold (0.01 log units) above the measured one, within the range that was stated.
By their numbers in this assay, from the lowest: compound 1; then compounds 2 and 3 (each within the scatter of the next).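

In this assay, vinyl in place of ethyl on a saturated chain carbon bound to an amine nitrogen in a ring gives a 1.2-fold higher number from compound 2 to compound 3 (0.08 log units; within the scatter) and so compound 2 and compound 3 cannot be told apart on this read-out, whether or not the chain holds a double bond. The earlier contrast with the shorter group now has a second instance: vinyl in place of hydrogen at the same place gives a 4.6-fold higher number from compound 1 to compound 3 (0.66 log units; beyond the scatter) and this lies beyond the scatter in the same direction as a 3.9-fold higher number from compound 1 to compound 2 (0.59 log units; beyond the scatter) so both compound 2 and compound 3 stand apart from compound 1, and no listed compound goes against this. Nothing available here bears on the reason for these numbers.

What the compounds shown leave open is whether a longer chain such as butyl, or a group carrying an aromatic ring such as benzyl or phenethyl, would continue this trend at this place. Going by these compounds, it also remains open how a triple bond, as in propargyl, or a small ring, as in cyclopropylmethyl, would compare with propyl and allyl on this read-out.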